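The source may hold more compounds than are shown below. What is called first, only, known or untested is meant among the compounds shown, and "the series" means these compounds.

Three compounds share one core and differ only in the group hanging from it. Compound 1 `Nc1cc(N)c2nc(-c3ccccc3)c(Oc3ccc(Cl)c(Cl)c3)nc2c1` carries an aryl ether; in a functional assay on SN12C cells (Homo sapiens) for inhibition, read by sulforhodamine B assay, with a stated time of 48 h (a lower number here means a stronger inhibitor of growth, a higher number a weaker inhibitor of growth), compound 1 gives 11500 nM. Compound 2 `Nc1cc(N)c2nc(-c3ccccc3)c(NCc3ccc(Cl)c(Cl)c3)nc2c1` carries a benzylamine, and in this assay compound 2 gives 6030 nM. Compound 3 `COc1cc(CNc2nc3cc(N)cc(N)c3nc2-c2ccccc2)cc(OC)c1OC`, also a benzylamine, gives in this assay 8710 nM. Compound 2 sits at the low end of these three numbers, yet its gaps to compound 3 and to compound 1 both lie within the usual scatter, so the three cannot be ranked.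

Compound 4 `COc1ccc(CNc2nc3cc(N)cc(N)c3nc2-c2ccccc2)cc1` keeps the benzylamine of compound 2 with one change: 4-methoxyphenyl in place of 3,4-dichlorophenyl on a saturated chain carbon bound to a nitrogen on an aromatic ring. Within the data shown here, no measured pair shows this change, so the step from compound 2 to compound 4 in this assay is expected to stay within the scatter, with no clear direction. Compound 4 is therefore estimated at 8000 nM, in the range 3000 nM to 20000 nM, a step of a 1.3-fold higher number from compound 2 to compound 4 (0.12 log units; within the scatter) expected.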

Compound 4, concentration for 50% growth inhibition: 17000 nM
For compound 4 the middle estimate is 2.1-fold (0.33 log units) below the measured one; the measured number falls inside the stated range.
By their numbers in this assay, from the lowest: compounds 2, 3, 1 and 4 (each within the scatter of the next, the first and the last beyond it).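

Replacing 3,4-dichlorophenyl with 4-methoxyphenyl on a saturated chain carbon bound to a nitrogen on an aromatic ring gives a 2.8-fold higher number from compound 2 to compound 4 (0.45 log units; beyond the scatter) in this assay and this is a modest step. Among these compounds, it shows that the aryl group at this position can shift growth inhibition beyond the scatter, which the earlier compounds could not show. No measurement here explains the step.

Going by these compounds, the change removes both chlorines and adds a methoxy group at once, so their separate contributions stay unknown. Plain phenyl or 4-chlorophenyl at this position could help separate them.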